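The source may hold more compounds than are shown below. What is called first, only, known or untested is meant among the compounds shown, and "the series" means these compounds.

Measured in a functional assay on A549 cells (Homo sapiens) for antiproliferative activity, with a stated time of 5 days; a higher number here means a weaker inhibitor, a lower number a stronger inhibitor:
compound 1 `CC1OC2(C=CC(=O)C=C2)N(c2nc(-c3cccc4ccccc34)nn2-c2ccccc2)C1=O`: 180 nM
compound 2 `O=C1C=CC2(C=C1)OCC(=O)N2c1nc(-c2ccc(F)c3ccccc23)nn1-c1ccccc1`: 320 nM
compound 3 `COc1ccc(-n2nc(-c3ccc4ccccc4c3)nc2N2C(=O)COC23C=CC(=O)C=C3)cc1`: 260 nM

Compound 2 gives the highest of the three numbers, yet its gap to compound 3 and its gap to compound 1 both lie within the scatter, so the three compounds cannot be separated on these numbers. Compound 4 `O=C1C=CC2(C=C1)OCC(=O)N2c1nc(-c2cccc(Cl)c2)nn1-c1ccccc1` is not yet measured. It differs from compound 2 in one place: 3-chlorophenyl in place of 4-fluoronaphthalen-1-yl on an aromatic carbon. For the measured compounds named here, no measured pair isolates this change, so nothing here calibrates it; two six-membered aromatic rings of carbon give way to one, with a chlorine in place of a fluorine. The expected step is a 2.2-fold higher number from compound 2 to compound 4 (0.34 log units; beyond the scatter), toward a weaker inhibitor, with a wide range. Compound 4 is expected to give 700 nM in this assay, between 200 nM and 2500 nM.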

Compound 4, half-maximal inhibitory concentration: 25.2 nM
For compound 4 the middle estimate is 28-fold (1.44 log units) above the measured one; measured number below the stated range.
By their numbers in this assay, from the lowest: compound 4; then compounds 1, 3 and 2 (each within the scatter of the next).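

On the aromatic carbon of the five-membered aromatic ring with 3 nitrogen, 3-chlorophenyl in place of 4-fluoronaphthalen-1-yl gives a 13-fold lower number from compound 2 to compound 4 (1.10 log units; beyond the scatter) in this assay. This position therefore keeps a large gain in this assay with one six-membered aromatic ring of carbon instead of two, so the second ring is not required here. No measurement at hand explains the step.

The ring count and the halogen change together, so their shares remain unresolved. From the compounds shown here alone, whether an amine or a carboxylic acid in place of the chlorine would hold this number also remains open.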